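A Larger Group on the Ring Nitrogen of Compound 1

The source may report more compounds than this note shows. Statements on the series, on what has been measured and on what is new or still open speak of the compounds shown alone.

Compound 1 `COC(=O)/C=C/c1ccc2c(c1)C(=O)C(=O)N2C` is the reference point here. In a functional assay on Jurkat cells (Homo sapiens) for antiproliferative activity, read by MTT assay, with a stated time of 48 h (on this read-out higher numbers stand for weaker inhibition and lower numbers for stronger inhibition), compound 1 gives 250 nM, the highest number of the three compounds measured, which makes it the weakest of the three. Compound 2 `COC(=O)/C=C/c1ccc2c(c1)C(=O)C(=O)N2Cc1ccccc1` gives 70 nM in this assay, and compound 3 `COC(=O)/C=C/c1ccc2c(c1)C(=O)C(=O)N2Cc1ccc(C#N)cc1` gives 80 nM. Each of these two carries an aromatic ring in place of a hydrogen on a saturated chain carbon bound to an amide-type nitrogen in a ring, and the two steps are alike in size: a 3.6-fold lower number from compound 1 to compound 2 (0.55 log units; beyond the scatter), and a 3.1-fold lower number from compound 1 to compound 3 (0.49 log units; beyond the scatter). Between the two ring-bearing compounds there is nothing to separate, since a 1.1-fold higher number from compound 2 to compound 3 (0.06 log units; within the scatter).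

Compound 4 `COC(=O)/C=C/c1ccc2c(c1)C(=O)C(=O)N2Cc1ccc(OC)cc1` has not yet been tested. Relative to compound 1 the change is 4-methoxyphenyl in place of hydrogen on a saturated chain carbon bound to an amide-type nitrogen in a ring. This is the same kind of change seen in compound 2 and compound 3, now with a methoxy group on the added ring. Because a 3.6-fold lower number from compound 1 to compound 2 (0.55 log units; beyond the scatter), and because a 3.1-fold lower number from compound 1 to compound 3 (0.49 log units; beyond the scatter), a modest lowering of the number is expected for compound 4 in this assay. The expected step is a 3.1-fold lower number from compound 1 to compound 4 (0.49 log units; beyond the scatter). Compound 4 is therefore estimated at 80 nM, with a range from 40 nM to 160 nM.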

Compound 4, half-maximal inhibitory concentration: 30 nM
Beside the measured number, compound 4's estimate is 2.7-fold (0.43 log units) above it; measured number outside the range, below it.
By their numbers in this assay, from the lowest: compound 4; then compounds 2 and 3 (each within the scatter of the next); then compound 1.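

Among these compounds, the added ring on the saturated chain carbon bound to an amide-type nitrogen in a ring can do more than compounds 2 and 3 suggested: in this assay, the 4-methoxyphenyl group gives an 8.3-fold lower number from compound 1 to compound 4 (0.92 log units; beyond the scatter), the largest drop seen at this position so far. What sits on the added ring also matters, which the earlier cyano pair could not show: methoxy in place of hydrogen gives a 2.3-fold lower number from compound 2 to compound 4 (0.37 log units; beyond the scatter) and methoxy in place of cyano gives a 2.7-fold lower number from compound 3 to compound 4 (0.43 log units; beyond the scatter), so compound 4 is the strongest of the four compounds. The data shown offer no explanation for this gain.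

With only cyano and methoxy on the added ring, two examples cannot show whether the gain is specific to methoxy or would extend to a group such as ethoxy, hydroxy, an amine or a carboxylic acid. On these data alone, it also remains open whether the gain would survive a longer chain between the ring nitrogen of the core and the added ring, or a change to the methyl ester that all four compounds share.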